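The compounds below may be only part of what the source reports. "The series", "measured", "known", "first", "only" and "open" are said of these compounds alone.

Compound 1 `CC(C)(N)CN(C(=O)[C@@H]1C[C@H]1c1ccccc1)c1ccc(-c2ccccc2)cc1` and compound 2 `CC[C@H](C)[C@H](N)CN(C(=O)[C@@H]1C[C@H]1c1cccc(F)c1)c1ccc(-c2ccccc2)cc1` share the same core but differ from each other in more than one place. In a functional assay for agonist activity at G protein-coupled receptor 88 (Homo sapiens), read by HTRF and cAMP accumulation (a higher number here means that more compound is needed for the effect, a lower number that less compound is needed), compound 1 gives 1.4 nM, while compound 2 gives 560 nM, the higher of the two numbers, and the gap between them lies beyond the usual scatter of this assay. Compound 3 `CC[C@H](C)[C@H](N)CN(C(=O)[C@@H]1C[C@H]1c1ccc(F)c(F)c1)c1ccc(-c2ccccc2)cc1` follows from compound 2 by a single change: fluoro in place of hydrogen on an aromatic carbon. Among the measured compounds shown here, no pair of measured compounds shows what this change does here, so nothing in the data points in one direction or the other. The step from compound 2 to compound 3 is therefore expected to be small, a 1.2-fold lower number from compound 2 to compound 3 (0.09 log units; within the scatter), and not clearly beyond the scatter. On that basis compound 3 is estimated at 450 nM in this assay, with a likely range from 120 nM to 1800 nM.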

Compound 3, half-maximal effective concentration: 720 nM
The estimate for compound 3 lay 1.6-fold (0.20 log units) below the measured number; the measured number falls inside the stated range.
By their numbers in this assay, from the lowest: compound 1; then compounds 2 and 3 (each within the scatter of the next).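

Adding a second fluoro, going from 3-fluorophenyl to 3,4-difluorophenyl, gives a 1.3-fold higher number from compound 2 to compound 3 (0.11 log units; within the scatter) in this assay and so does not move the number by more than the assay can resolve. This is the first measured example of this change among these compounds, and it shows that a fluoro can stand on this aromatic carbon, ortho to a fluoro group and para to a large group, without a clear effect on the read-out. No measured data here offer an explanation for this result.

As far as these compounds go, whether a chloro, methyl, methoxy or trifluoromethyl group at the same place would also leave the number unchanged remains open. From the compounds shown here alone, it is also open whether the same fluoro would have so little effect on the core of compound 1, which carries an unsubstituted phenyl group and a different amine side chain.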